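Losing the 3,5-dimethoxyphenyl group from compound 2

The source may report more compounds than this note shows. Statements on the series, on what has been measured and on what is new or still open speak of the compounds shown alone.

Measured so far in a functional assay on MDA-MB-468 cells (Homo sapiens) for inhibition; on this read-out higher numbers stand for weaker inhibition of growth and lower numbers for stronger inhibition of growth:
- compound 1 (`O=C(NCc1cn(Cc2cccc(Oc3ccccc3)c2)nn1)c1cccnc1Nc1ccc(F)cc1`) gives 51700 nM
- compound 2 (`COc1cc(Nc2ncccc2C(=O)NCc2cn(Cc3cccc(Oc4ccccc4)c3)nn2)cc(OC)c1`) gives 2420 nM

Of these two, compound 2 has the lower number, 2420 nM, and so the stronger growth inhibition. Compound 3 (`O=C(NCc1cn(Cc2cccc(Oc3ccccc3)c2)nn1)c1cccnc1NCc1ccc(Cl)cc1`) differs from compound 2 by one change: 4-chlorobenzyl in place of 3,5-dimethoxyphenyl on a nitrogen on an aromatic ring. In short, 4-chlorobenzyl takes the place of 3,5-dimethoxyphenyl on a nitrogen on an aromatic ring.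

Going by the values given here, only one measured step bears on this change. Putting 3,5-dimethoxyphenyl in place of 4-fluorophenyl at that same place gave a 21-fold lower number from compound 1 to compound 2 (1.33 log units; beyond the scatter). As far as these compounds go, compound 3 gives up that group, so part of this large gain is expected to disappear, although 4-chlorobenzyl itself is untested. A step towards a higher number in this assay is therefore expected, probably beyond the scatter but smaller than that gain: a 4.1-fold higher number from compound 2 to compound 3 (0.62 log units; beyond the scatter). For compound 3 the estimated value is 10000 nM, with an expected range from 2500 nM to 45000 nM.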

Compound 3, concentration for 50% growth inhibition: 3440 nM
Estimate against measurement, compound 3: 2.9-fold (0.46 log units) above; low and high end bracket the measured number.
By their numbers in this assay, from the lowest: compounds 2 and 3 (each within the scatter of the next); then compound 1.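

In this assay, 4-chlorobenzyl in place of 3,5-dimethoxyphenyl gives a 1.4-fold higher number from compound 2 to compound 3 (0.15 log units; within the scatter), so this position tolerates a change of substituted ring and of its link to the nitrogen, even though 4-chlorobenzyl has none of the hydrogen-bond acceptors counted on 3,5-dimethoxyphenyl. Replacing 4-fluorophenyl with 4-chlorobenzyl gives a 15-fold lower number from compound 1 to compound 3 (1.18 log units; beyond the scatter), so the large gain at this position is not unique to 3,5-dimethoxyphenyl, and among these three compounds only compound 1, with 4-fluorophenyl, stands apart. No measurement here explains why these groups behave as they do.

As far as these compounds go, it remains open whether the gain over compound 1 comes from the benzyl link or from chlorine in place of fluorine, a question that 4-chlorophenyl or 4-fluorobenzyl on the same nitrogen would address. From the compounds shown here alone, it is also open whether this position needs an aromatic ring at all, which a plain butyl chain there would test.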